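The source may report more compounds than this note shows. Statements on the series, on what has been measured and on what is new or still open speak of the compounds shown alone.

Working notes on the step from compound 3 to compound 4.

In a functional assay on JeKo-1 cells (Homo sapiens) for inhibition, read by luminescence and CellTiter-Glo, with a stated time of 72 h (a higher number here means a weaker inhibitor, a lower number a stronger inhibitor), compound 1 (`O=C(O)c1cc(-c2ccc(Oc3ccccc3)cc2)nn1C1CCCN(C(=O)CCl)C1`) gives 3600 nM and compound 2 (`C/C=C/C(=O)N1CCCC(n2nc(-c3ccc(Oc4ccccc4)cc3)cc2C(=O)OCC)C1`) gives 26500 nM. Compound 3 (`C=CC(=O)N1CCCC(n2nc(-c3ccc(Oc4ccccc4)cc3)cc2C(=O)O)C1`) reads > 60000 nM, which is a limit of the assay and not a number, so its position is bounded on one side only.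

Compound 4 (`C/C=C/C(=O)N1CCCC(n2nc(-c3ccc(Oc4ccccc4)cc3)cc2C(=O)O)C1`) differs from compound 3 by prop-1-en-1-yl in place of vinyl on a carbonyl carbon. Among the measured compounds shown here, one measured step bears on this place: an at least 16-fold higher number from compound 1 to compound 3 (1.22 log units; beyond the scatter). That step is large, with vinyl in place of chloromethyl on the same carbonyl carbon, but it leaves a different group and ends at a limit. For the measured compounds named here, no measured step joins compound 2 to compound 4 in one place.

Compound 4 is expected to stay weak in this assay, with no clear gain on compound 3 and quite possibly another limit as the reported result. The expected size is a number no higher from compound 3 to compound 4 (the limit leaves the size open), and no change beyond the scatter is expected. For compound 4 the estimated value is 60000 nM, with an expected range from 25000 nM to 120000 nM.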

Compound 4, half-maximal inhibitory concentration: > 60000 nM
Compound 4 gave a limit, no number; the forecaster's own chance of this, stated with the estimate: 65%; the middle value sits exactly at the limit.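

In this assay compound 4 gives > 60000 nM, which is a limit of the assay and not a number. The change from vinyl to prop-1-en-1-yl on the carbonyl carbon cannot be read, since compound 3 and compound 4 both end at the same limit: the limit of > 60000 nM in this assay, at which 2 of the 4 values shown sit. What is new comes from the other two steps: prop-1-en-1-yl in place of chloromethyl on the carbonyl carbon gives an at least 16-fold higher number from compound 1 to compound 4 (1.22 log units; beyond the scatter), and hydrogen in place of ethyl on an oxygen next to a carbonyl group gives an at least 2.2-fold higher number from compound 2 to compound 4 (0.35 log units; beyond the scatter), so with prop-1-en-1-yl in place the ethyl ester reads stronger than the carboxylic acid.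

As far as these compounds go, how vinyl and prop-1-en-1-yl compare with each other stays open. Also open, from the compounds shown here alone, is how a longer chain carrying an amine on that carbonyl carbon would read, with either the ethyl ester or the carboxylic acid.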